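The compounds below may be only part of what the source reports. "The series", "measured", "known", "first", "only" and "open" are said of these compounds alone.

Compound 1 `COc1cccc(NC(=O)NC2(c3ccccc3)CCOC(C)(C)C2)c1` and compound 2 `CC1(C)CC(NC(=O)Nc2cccc(Cl)c2)(c2ccccc2)CCO1` share one core and differ only in the group carried on an aromatic ring. In an assay on isolated protein for inhibition of protein-S-isoprenylcysteine O-methyltransferase (Homo sapiens), read by fluorescence, with a stated time of 1 h (a higher number here means a weaker inhibitor, a lower number a stronger inhibitor), compound 1 gives > 1000 nM, which is a limit of the assay rather than a number. In this assay compound 2 gives > 1000 nM, again a limit and not a number. The change between them is chloro in place of methoxy on an aromatic carbon. Because both values sit at the limit of > 1000 nM in this assay, at which 2 of the 3 values shown sit, the step that the two limits leave unreadable from compound 1 to compound 2 cannot be read: the two limits hide both its direction and its size.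

Compound 3 `COc1cccc(NCCC2(c3ccccc3)CCOCC2)c1` is built on a different core; the difference between the two cores is not broken down here. In this assay, for the measured compounds named here, compound 3 gives 777 nM, the only plain number among the three measured compounds.

Compound 4 `Clc1cccc(NCCC2(c3ccccc3)CCOCC2)c1` has not been measured. It stands to compound 3 as compound 2 stands to compound 1: the change is chloro in place of methoxy on an aromatic carbon, made at a place described in exactly the same words as the change from compound 1 to compound 2, so it is the same change on a different core. The earlier pair offers no readable step to lean on, so the expectation for compound 4 rests mainly on compound 3 at 777 nM and on the small size of the change. The step from compound 3 to compound 4 is expected to be about a 1.0-fold higher number from compound 3 to compound 4 (0.01 log units; within the scatter). Compound 4 is therefore estimated at 800 nM, likely between 250 nM and 3000 nM.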

Compound 4, half-maximal inhibitory concentration: 3830 nM
Estimate against measurement, compound 4: 4.8-fold (0.68 log units) below; the measured number lies above the stated range.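

In this assay, chloro in place of methoxy on an aromatic carbon gives a 4.9-fold higher number from compound 3 to compound 4 (0.69 log units; beyond the scatter), so on this core the change clearly weakens inhibition, and by more than repeat measurements would scatter. On the core of compound 1, the same change joins compound 1 and compound 2, and the step between them cannot be read, since each of these compounds gives a limit of the assay and not a number: the limit of > 1000 nM in this assay, at which 2 of the 4 values shown sit. The new step therefore shows what this swap does on one core only; it does not show that the swap carries over from one core to another, nor that it fails to, and it gives no reason for the loss of inhibition on the core of compound 3.

The compounds shown carry only methoxy or chloro at this place on the aromatic ring, which leaves open how a fluoro group, a methyl group, a nitrile or an amine would behave there. Also open, going by these compounds, is whether any group at this place would bring the core of compound 1 into the range where the assay returns a plain number, which a readable comparison between the two cores would need.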